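The source may report more compounds than this note shows. Statements on the series, on what has been measured and on what is new or still open speak of the compounds shown alone.

For the measured compounds named here, in a functional assay on SW1573 cells (Homo sapiens) for antiproliferative activity, read by sulforhodamine B assay, with a stated time of 48 h (on this read-out lower numbers stand for stronger inhibition of growth and higher numbers for weaker inhibition of growth), only one of the three compounds tested so far returns an actual number: compound 1 `COC(=O)C#CC(O/C=C/C(=O)OC)C1CCCCC1` gives 2100 nM as its measured value. Compound 2 `COC(=O)/C=C/OC(C#CC(=O)O)C(C)(C)C` gives > 100000 nM as its reading, which is a limit of the assay and not a number. Compound 3 `C#CCO/C=C/C(=O)OC` gives > 100000 nM as its reading, which is again a limit. Compound 1 therefore stands alone with a true value, while the other two sit at the same limit (the limit of > 100000 nM in this assay, at which 2 of the 3 values shown sit).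

Going by the values given here, no two measured compounds differ in just one place, so no measured step is available as a guide for the next compound. Compound 4 `COC(=O)C#CC(O/C=C/C(=O)OC)C(C)C` keeps the core of compound 1 and changes one group: isopropyl in place of cyclohexyl on a saturated chain carbon bound to an oxygen on an unsaturated carbon and a triple-bonded carbon is the difference, with isopropyl in place of cyclohexyl on a saturated chain carbon bound to an oxygen on an unsaturated carbon and a triple-bonded carbon.

In this assay a modest weakening is expected, perhaps not far beyond the usual scatter, with compound 1 at 2100 nM as the only anchor. Going by these compounds, the expected change is a 1.7-fold higher number from compound 1 to compound 4 (0.22 log units; within the scatter) as estimated here, and its true size remains open. Compound 4 is expected at 3500 nM by this estimate, with a likely range from 1200 nM to 12000 nM for the measurement.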

Compound 4, concentration for 50% growth inhibition: 750 nM
Estimate against measurement, compound 4: 4.7-fold (0.67 log units) above; the whole stated range lies above it.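

In this assay, for the compounds shown here, placing isopropyl in place of cyclohexyl on a saturated chain carbon bound to an oxygen on an unsaturated carbon and a triple-bonded carbon gives a 2.8-fold lower number from compound 1 to compound 4 (0.45 log units; beyond the scatter), the first step in this set that can be read, and it shows that growth inhibition responds to the group held at this position. In this pair, the six-membered ring of carbon is not needed for activity: the open-chain isopropyl, with fewer heavy atoms than cyclohexyl, gives the stronger inhibition of growth. Nothing given here explains the difference between these two compounds.

Going by these compounds, a single pair cannot show a trend, so it remains open whether a smaller methyl, a longer chain such as n-butyl or a phenyl ring at this position would strengthen or weaken inhibition of growth. On these data alone, it also remains open how a carboxylic acid or an amine would fare on the core of compound 4, since compound 2 and compound 3 each differ from compound 1 and compound 4 in more than one place and cannot answer that question.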